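This account rests on a few compounds, and the source may have more. Where it says the series, first, only, none or still open, it means among the compounds named here.

Measured compounds in a functional assay with Homo sapiens as the target; a higher number here means a weaker inhibitor, a lower number a stronger inhibitor:

Compound 1, `CC(C)[C@H](NC(=O)COc1cccc2ccccc12)C(=O)N[C@@H](CC(=O)O)C(=O)COc1cccc2ccccc12`, gives 19000 nM.
Compound 2, `CC(C)[C@H](NC(=O)COc1cccc2ccccc12)C(=O)N[C@@H](CC(=O)O)C(=O)COc1cccc(C(F)(F)F)c1`, gives 16600 nM.
Compound 3, `CC(C)[C@H](NC(=O)COc1cccc2ccccc12)C(=O)N[C@@H](CC(=O)O)C(=O)COc1ccc(F)c(F)c1`, gives 16200 nM.

Compound 2 stands second highest of the three numbers, but every gap among them is within the scatter: a 1.1-fold lower number from compound 1 to compound 2 (0.06 log units; within the scatter), a 1.2-fold lower number from compound 1 to compound 3 (0.07 log units; within the scatter) and a 1.0-fold lower number from compound 2 to compound 3 (0.01 log units; within the scatter). Each of these steps changes only the aryl group on an oxygen on a saturated carbon, and none of them moved the read-out beyond the scatter.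

Compound 4, `CC(C)[C@H](NC(=O)COc1cccc2ccccc12)C(=O)N[C@@H](CC(=O)O)C(=O)COc1cc(F)cc(F)c1F`, is not yet measured. Relative to compound 2 it carries 2,3,5-trifluorophenyl in place of 3-(trifluoromethyl)phenyl on an oxygen on a saturated carbon

All three measured steps bear on this change, since they vary the same group at the same place, and all three were within the scatter. Among the compounds with values here, there is no measured step that shows a fluorinated phenyl at this position, or any other aryl group there, shifting the read-out beyond the scatter. The expectation for this assay is therefore a step within the scatter, with no direction favoured, so a 1.0-fold lower number from compound 2 to compound 4 (0.00 log units; within the scatter) is expected.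

Compound 4 is estimated at 16500 nM in this assay, with a range from 8000 nM to 34000 nM.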

Compound 4, half-maximal inhibitory concentration: 11200 nM
For compound 4 the middle estimate is 1.5-fold (0.17 log units) above the measured one; the range from low to high includes it.
By their numbers in this assay, from the lowest: compounds 4, 3, 2 and 1 (each within the scatter of the next).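

In this assay, the 2,3,5-trifluorophenyl group on an oxygen on a saturated carbon stays within the scatter of all three other aryl groups (a 1.5-fold lower number from compound 2 to compound 4 (0.17 log units; within the scatter)), (a 1.4-fold lower number from compound 3 to compound 4 (0.16 log units; within the scatter)) and (a 1.7-fold lower number from compound 1 to compound 4 (0.23 log units; within the scatter)). Within the data shown here, the tolerated range at this position therefore now includes a third fluorine pattern alongside trifluoromethyl, difluoro and naphthalen-1-yl variants, and even the widest step in the set, the one from the naphthalen-1-yl group, does not pass beyond the scatter. No measured evidence bears on why the read-out stays so flat across these groups.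

As far as these compounds go, all four groups at this position are carbon-only aromatic rings carrying fluorine or trifluoromethyl, or no substituent at all, so it remains open whether an amine or a carboxylic acid on the phenyl group would shift this assay beyond the scatter. The rest of the shared core is the same in all four compounds, which leaves open how much of the read-out depends on other parts of the molecule, such as the naphthalen-1-yl group at the far end or the free carboxylic acid.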